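Compound 3 trades 1H-benzimidazol-2-yl for 1,3-benzoxazol-2-yl

The compounds below may be only part of what the source reports. "The series", "measured", "known", "first", "only" and "open" are said of these compounds alone.

In a functional assay on K562 cells (Homo sapiens) for antiproliferative activity, read by MTT assay, with a stated time of 48 h (a higher number here means a weaker inhibitor, a lower number a stronger inhibitor), compound 1 `CN(C)CCn1c(N)c(-c2nc3ccccc3[nH]2)c2nc(C#N)c(C#N)nc21` gives 6340 nM. For compound 2 `N#Cc1nc2c(-c3nc4ccccc4[nH]3)c(N)n(CCO)c2nc1C#N` the assay reports only a limit, > 50000 nM. Compound 3 `CCN(CC)CCCCn1c(N)c(-c2nc3ccccc3[nH]2)c2nc(C#N)c(C#N)nc21` stands lowest, at 1440 nM. The measured changes are an at least 7.8-fold higher number from compound 1 to compound 2 (0.89 log units; beyond the scatter), a 4.4-fold lower number from compound 1 to compound 3 (0.64 log units; beyond the scatter) and an at least 34-fold lower number from compound 2 to compound 3 (1.54 log units; beyond the scatter), all on the saturated chain. Compound 4 `CCN(CC)CCCCn1c(N)c(-c2nc3ccccc3o2)c2nc(C#N)c(C#N)nc21` keeps the chain of compound 3 and changes an aromatic carbon's substituent instead: 1,3-benzoxazol-2-yl in place of 1H-benzimidazol-2-yl on an aromatic carbon. For the measured compounds named here, none of the measured steps tests this swap, so they set no size for it. In this assay only a small move toward a higher number is expected, near the scatter. That means an expected 1.6-fold higher number from compound 3 to compound 4 (0.20 log units; within the scatter). Compound 4 is estimated at 2300 nM, within a range of 600 nM to 9000 nM.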

Compound 4, half-maximal inhibitory concentration: 1980 nM
Beside the measured number, compound 4's estimate is 1.2-fold (0.07 log units) above it; measured number inside the range.
By their numbers in this assay, from the lowest: compounds 3 and 4 (each within the scatter of the next); then compound 1. At a limit, above all of these: compound 2.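

The earlier steps shown here all changed the saturated chain, whereas this one changes the group on the aromatic carbon, and in this assay it gives a 1.4-fold higher number from compound 3 to compound 4 (0.14 log units; within the scatter). With the 4-(diethylamino)butyl group in place, 1H-benzimidazol-2-yl, with 1 hydrogen-bond donor, can therefore give way to 1,3-benzoxazol-2-yl, with 0 hydrogen-bond donors, without a change beyond the scatter. No measurement shown here bears on why this is so.

From the compounds shown here alone, it remains open how 1,3-benzothiazol-2-yl, with sulfur in place of the oxygen, would read at this carbon. Going by these compounds, the same swap on the shorter dimethylamino chain of compound 1 also remains open.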